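The source may report more compounds than this note shows. Statements on the series, on what has been measured and on what is new or still open speak of the compounds shown alone.

Measured in an ADME assay on HEK293 cells (Homo sapiens) for cytotoxicity, read by CCK-8 assay, with a stated time of 48 h; on this read-out lower numbers stand for stronger inhibition and higher numbers for weaker inhibition:
- compound 1 `COc1ccc(/C=C\c2cc(OC)c(OC)c(OC)c2)cc1OCc1ccc(C=O)cc1`: 46000 nM
- compound 2 `COc1ccc(/C=C\c2cc(OC)c(OC)c(OC)c2)cc1OCc1ccc(CN2C[C@H](O)C[C@@H]2C(=O)O)cc1`: > 50000 nM, a limit
- compound 3 `COc1ccc(/C=C\c2cc(OC)c(OC)c(OC)c2)cc1OCc1ccc(CN2CCCCC2C(=O)O)cc1`: > 50000 nM, a limit

Compound 3 has no exact number, only a limit. It shares this position with compound 2, as the limit of > 50000 nM in this assay, at which 2 of the 3 values shown sit, shows.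

Compound 4 `COc1ccc(/C=C\c2cc(OC)c(OC)c(OC)c2)cc1OCc1ccc(CNCCO)cc1` has not yet been measured. It differs from compound 3 as follows: (2-hydroxyethyl)amino in place of 2-carboxypiperidin-1-yl on a saturated chain carbon bound to an aromatic carbon. In words, (2-hydroxyethyl)amino stands in place of 2-carboxypiperidin-1-yl on a saturated chain carbon bound to an aromatic carbon.

Going by the values given here, three measured steps bear on this change, all at the same place on the shared core. Two of them start from the formyl group: an at least 1.0-fold higher number from compound 1 to compound 2 (0.03 log units; that floor lies within the scatter) and an at least 1.0-fold higher number from compound 1 to compound 3 (0.03 log units; that floor lies within the scatter). Neither floor goes beyond the scatter. The third, a step that the two limits leave unreadable from compound 2 to compound 3, cannot be sized.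

Compound 1, with formyl at this place, gives 46000 nM, so no large drop is expected. The expected change is small, an at least 1.1-fold lower number from compound 3 to compound 4 (0.07 log units; that floor lies within the scatter), and any readable shift should be towards a lower number. For compound 4 the estimated value is 42000 nM, with an expected range of 15000 nM to 100000 nM.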

Compound 4, half-maximal inhibitory concentration: > 50000 nM
Compound 4: only a limit was reported; the forecaster's own chance of this, stated with the estimate: 50%; at least 1.1-fold (0.07 log units) between middle value and limit.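

In this assay, swapping 2-carboxypiperidin-1-yl for the smaller, ring-free (2-hydroxyethyl)amino leaves the result at the same limit, so this place now holds three different amine groups with no exact number among them: the limit of > 50000 nM in this assay, at which 3 of the 4 values shown sit.

The steps among compound 2, compound 3 and compound 4 cannot be read, as each joins two limits. Going by these compounds alone, the only readable step is an at least 1.0-fold higher number from compound 1 to compound 4 (0.03 log units; that floor lies within the scatter), so the change from formyl to ((2-hydroxyethyl)amino)methyl shows no difference beyond that scatter.

Going by these compounds, how far the true values of compound 2, compound 3 and compound 4 lie past the limit remains unknown. Also open, on these data alone, is whether another group at this place, such as dimethylamino or a longer chain ending in a primary amine, would give an exact number in this assay.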